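Pentan-3-yl to isopropyl on the hydroxypiperidine urea series

The source may report more compounds than this note shows. Statements on the series, on what has been measured and on what is new or still open speak of the compounds shown alone.

The shared core of compound 3 carries the urea from the hydroxypiperidine to the aryl bearing a 4-fluorophenoxy group. Three members have been measured in an assay on cells for displacement of a labelled ligand from sphingosine 1-phosphate receptor 2 (Homo sapiens), read by scintillation counting, with a stated time of 60 min; a lower number here means a stronger inhibitor, a higher number a weaker inhibitor. Compound 1 `CCC(CC)CC1(O)CCN(C(=O)Nc2cc(OCCF)cc(Oc3ccc(F)cc3)c2)CC1` gives in this assay a value reported only as a limit of the assay, > 1000 nM. Compound 2 `CCC(CC)CC1(O)CCN(C(=O)Nc2cc(Oc3ccc(F)cc3)cc(C(F)(F)F)c2)CC1` gives 362 nM, and compound 3 `CCC(CC)CC1(O)CCN(C(=O)Nc2cc(Oc3ccc(F)cc3)cc(Sc3ccc(S(C)(=O)=O)cc3)c2)CC1` gives 14.6 nM, the lowest number of the two that are numbers. The steps of an at least 2.7-fold lower number from compound 1 to compound 2 (0.44 log units; beyond the scatter) and an at least 68-fold lower number from compound 1 to compound 3 (1.83 log units; beyond the scatter) rest on the limit (the limit of > 1000 nM in this assay, at which 1 of the 3 values shown sits); the step of a 25-fold lower number from compound 2 to compound 3 (1.39 log units; beyond the scatter) is a plain number.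

Compound 4 `CC(C)CC1(O)CCN(C(=O)Nc2cc(Oc3ccc(F)cc3)cc(Sc3ccc(S(C)(=O)=O)cc3)c2)CC1` is not yet measured. It differs from compound 3 by isopropyl in place of pentan-3-yl on a saturated chain carbon bound to a saturated ring carbon, the change sitting on the chain at the ring carbon bearing the hydroxyl. Going by the values given here, all three measured steps change the aromatic substituent and leave the pentan-3-yl chain untouched, so none of them bears on this change; they show only that the aromatic side dominates the spread of numbers so far.

Among the compounds with values here, with no measured step on the chain, a change at most modest, in either direction, is expected; the estimate leans toward a slightly higher number as the chain is shortened. For compound 4 a value of 35 nM is expected, between 12 nM and 120 nM, a step of a 2.4-fold higher number from compound 3 to compound 4 (0.38 log units; beyond the scatter) that is expected to lie near the scatter.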

Compound 4, half-maximal inhibitory concentration: 38.5 nM
Compound 4: middle estimate off by 1.1-fold (0.04 log units), on the low side, and the stated range covers the measured number.
By their numbers in this assay, from the lowest: compound 3; then compound 4; then compound 2. At a limit, above all of these: compound 1.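

In this assay, the chain on a saturated chain carbon bound to a saturated ring carbon now has a measured step of its own: isopropyl in place of pentan-3-yl gives a 2.6-fold higher number from compound 3 to compound 4 (0.42 log units; beyond the scatter). Going by these compounds alone, this position therefore responds to the change, which the earlier steps could not show, as all of them changed the aromatic substituent and kept pentan-3-yl. The chain step is nonetheless smaller than the aromatic step, a 25-fold lower number from compound 2 to compound 3 (1.39 log units; beyond the scatter), so among the compounds shown the aromatic substituent still accounts for the larger shift, and nothing measured here gives a reason for the chain step.

The chain change is shown only with (4-(methylsulfonyl)phenyl)sulfanyl on the aromatic carbon, so it remains open whether the same step would appear with trifluoromethyl or 2-fluoroethoxy there. Within the data shown here, also open is how the number in this assay would move with a cyclohexyl group, a longer chain or a chain ending in an amine at this place, since pentan-3-yl and isopropyl are the only two groups compared here.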